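Trifluoropropyl Sulfonate in Place of Chlorophenyl Sulfonate

This account rests on a few compounds, and the source may have more. Where it says the series, first, only, none or still open, it means among the compounds named here.

Measured compounds:
compound 1 `CNC(=O)/C=C1/COc2cc(OS(=O)(=O)c3cccc(Cl)c3)ccc21`: 0%
compound 2 `CNC(=O)/C=C1/COc2cc(OS(=O)(=O)c3ccc(Cl)cc3)ccc21`: 6%
compound 3 `CNC(=O)/C=C1/COc2c1ccc(OS(=O)(=O)c1ccccc1)c2C`: 5%

In an assay (strain Sprague-Dawley) for inhibition of Amine oxidase [flavin-containing] B (Rattus norvegicus), read by spectrophotometry, with a stated time of 5 min, tested at 10 uM (on this read-out higher numbers stand for more inhibition at the one concentration tested (going by the name of the read-out) and lower numbers for less inhibition), compound 1 gives 0%, numerically the smallest of the three numbers, yet compound 3 with 5% and compound 2 with 6% both sit within the usual scatter of it. Going by the values given here, the only single-place step among the measured compounds, a number 6 percentage points higher from compound 1 to compound 2 (within the scatter), is likewise within the scatter. Compound 4 `CNC(=O)/C=C1/COc2cc(OS(=O)(=O)CCC(F)(F)F)ccc21` differs from compound 1 by 3,3,3-trifluoropropyl in place of 3-chlorophenyl on a sulfonyl sulfur. Among the compounds with values here, no measured step touches this kind of change, so the expectation for compound 4 rests on the flat numbers seen so far. The step of a number 5 percentage points higher from compound 1 to compound 4 (within the scatter) is expected to stay within the scatter. Compound 4 is therefore estimated at 5%, with a range from 0% to 20%.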

Compound 4, a percentage reported as inhibition, at one concentration (the size of the read-out at that concentration, not a potency): 17%
Compound 4: the middle estimate sits 12 percentage points below what was measured; the range from low to high includes it.
By their numbers in this assay, from the lowest: compounds 1, 3 and 2 (each within the scatter of the next); then compound 4.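

In this assay there is a number 17 percentage points higher from compound 1 to compound 4 (beyond the scatter) and likewise a number 11 percentage points higher from compound 2 to compound 4 (beyond the scatter) at the same sulfonyl sulfur. Among the compounds shown, replacing a chlorophenyl with 3,3,3-trifluoropropyl is thus the first change at this place to move the number beyond the scatter, and inhibition there does not depend on an aromatic ring on the sulfur. Nothing available explains this gain. The compounds shown leave open whether the fluorines or the loss of the ring matters, which a plain propyl chain could separate. From the compounds shown here alone, how a longer chain would behave on this sulfur also remains open.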